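The compounds below may be only part of what the source reports. "The series", "measured", "known", "first", "only" and "open" are said of these compounds alone.

In a functional assay for inhibition of sodium/hydrogen exchanger (Oryctolagus cuniculus) (on this read-out higher numbers stand for weaker inhibition and lower numbers for stronger inhibition), three compounds have been measured: compound 1 `Cc1cc(C2CCC2)c(S(C)(=O)=O)cc1C(=O)N=C(N)N` gives 8.2 nM, compound 2 `Cc1cc(SC(C)C)c(S(C)(=O)=O)cc1C(=O)N=C(N)N` gives 12 nM, and compound 3 `Cc1cc(SC(C)(C)C)c(S(C)(=O)=O)cc1C(=O)N=C(N)N` gives 22 nM.

Compound 3 holds the highest number of the three. The step of a 1.8-fold higher number from compound 2 to compound 3 (0.26 log units; within the scatter) lies within the scatter, whereas the step of a 2.7-fold higher number from compound 1 to compound 3 (0.43 log units; beyond the scatter) goes beyond it, and the step of a 1.5-fold higher number from compound 1 to compound 2 (0.17 log units; within the scatter) also stays within the scatter.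

Compound 4 `Cc1cc(OCc2ccccc2)c(S(C)(=O)=O)cc1C(=O)N=C(N)N` differs from compound 3 in one place: benzyloxy in place of (tert-butyl)sulfanyl on an aromatic carbon. Among the compounds with values here, no measured step exchanges a sulfanyl group for an ether, and none brings in an aromatic ring, so the three steps bear on it only loosely; all of them were small. In this assay compound 4 is therefore expected to show a 1.1-fold higher number from compound 3 to compound 4 (0.06 log units; within the scatter), at most a modest shift. The estimate for compound 4 is 25 nM, with a range from 8 nM to 80 nM.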

Compound 4, half-maximal inhibitory concentration: 28 nM
Compound 4: middle estimate off by 1.1-fold (0.05 log units), on the low side, and the stated range covers the measured number.
By their numbers in this assay, from the lowest: compounds 1, 2, 3 and 4 (each within the scatter of the next, the first and the last beyond it).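

The aromatic carbon ortho to a methylsulfonyl group takes benzyloxy, with its six-membered aromatic ring, and the result cannot be told apart from (tert-butyl)sulfanyl: the data give a 1.3-fold higher number from compound 3 to compound 4 (0.10 log units; within the scatter). Against isopropylsulfanyl and cyclobutyl the gaps remain modest, with a 2.3-fold higher number from compound 2 to compound 4 (0.37 log units; beyond the scatter) and a 3.4-fold higher number from compound 1 to compound 4 (0.53 log units; beyond the scatter). No supporting evidence accounts for these differences. As far as these compounds go, it remains open whether the ether oxygen or the aromatic ring matters more, and how an amine or a carboxylic acid would fare on this aromatic carbon.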